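The compounds below may be only part of what the source reports. "The series", "measured", "known", "first", "only" and "open" are said of these compounds alone.

Measured compounds in a functional assay on HCT-116 cells (Homo sapiens) for inhibition, read by sulforhodamine B assay, with a stated time of 72 h; on this read-out higher numbers stand for weaker inhibition and lower numbers for stronger inhibition:
compound 1 `COc1ccc(C(=O)/C=C/c2cn(-c3ccccc3)nc2-c2ccsc2)c(OC)c1OC` gives 5800 nM
compound 2 `COc1ccc(OC)c(C(=O)/C=C/c2cn(-c3ccccc3)nc2-c2ccsc2)c1` gives 3400 nM
compound 3 `O=C(/C=C/c1cn(-c2ccccc2)nc1-c1cccnc1)c1c[nH]c2ccccc12` gives 6400 nM

Compound 3 carries the highest number of the three; compound 1 sits nearest to it and compound 2 furthest, and both gaps lie within the scatter, so no order among the three can be read from these numbers.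

Compound 4 `COc1ccc(OC)c(C(=O)/C=C/c2cn(-c3ccccc3)nc2-c2cccnc2)c1` is not yet measured. It differs from compound 3 by 2,5-dimethoxyphenyl in place of 1H-indol-3-yl on a carbonyl carbon. Within the data shown here, no measured pair shows this change in isolation. Compound 2 carries the same 2,5-dimethoxyphenyl group on the carbonyl carbon with a different group on the core, and with 3400 nM it falls within the scatter of compound 3. The step from compound 3 to compound 4 is therefore expected to be small, a 1.6-fold lower number from compound 3 to compound 4 (0.20 log units; within the scatter), slightly downward if anything and not beyond the scatter. For compound 4 the estimate is 4000 nM, with a range from 1500 nM to 11000 nM.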

Compound 4, half-maximal inhibitory concentration: 1000 nM
Compound 4: the middle estimate sits 4.0-fold (0.60 log units) above what was measured, and the stated range ends above it.
By their numbers in this assay, from the lowest: compound 4; then compounds 2, 1 and 3 (each within the scatter of the next).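

In this assay, the group on the carbonyl carbon matters: 2,5-dimethoxyphenyl in place of 1H-indol-3-yl gives a 6.4-fold lower number from compound 3 to compound 4 (0.81 log units; beyond the scatter). The group on the aromatic carbon of the core matters too, with pyridin-3-yl in place of thiophen-3-yl giving a 3.4-fold lower number from compound 2 to compound 4 (0.53 log units; beyond the scatter). No evidence on the cause of either step is at hand.

From the compounds shown here alone, each change is seen only once, so whether either step carries over to other partners on the shared core stays open. Also open, going by these compounds, is how a carboxylic acid or an amine would fare in place of the methoxy groups.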